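This account rests on a few compounds, and the source may have more. Where it says the series, first, only, none or still open, it means among the compounds named here.

The account concerns a small set of compounds built on a shared core and read in a functional assay on A-375 cells (Homo sapiens) for antiproliferative activity, read by CCK-8 assay, with a stated time of 72 h, tested at 2 uM; a lower number here means a weaker effect, a higher number a stronger effect of the compound at the concentration tested. Compound 1 `Nc1ccccc1NC(=O)c1ccc(CSC(=S)N2CCCc3ccccc32)cc1` gives 26.5% in this assay. Compound 2 `Nc1ccccc1NC(=O)c1ccc(CSC(=S)N2CCc3cc(Cl)ccc32)cc1` gives 31.9% in this assay, and the single-place step from compound 1 to compound 2 is a number 5.4 percentage points higher from compound 1 to compound 2 (within the scatter), a change on the thiocarbonyl carbon that leaves the read-out where it was. Compound 3 `Nc1ccccc1NC(=O)c1ccc(CSC(=S)N2CCN(Cc3ccncc3)CC2)cc1` gives 33.1% in this assay; this is the highest of the three numbers, yet its distance to compound 2 and to compound 1 stays within the scatter, so the three cannot be ranked.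

Compound 4 `Nc1ccccc1NC(=O)c1ccc(CSC(=S)N2CCN(c3cnccn3)CC2)cc1` differs from compound 3 by pyrazin-2-yl in place of (pyridin-4-yl)methyl on an amine nitrogen in a ring. Within the data shown here, no measured step bears directly on this place: the one step available, from compound 1 to compound 2, alters the group on the thiocarbonyl carbon, not the amine nitrogen in the ring, and it was within the scatter. Among the measured compounds shown here, compounds 1 and 2 differ from compound 3 in more than one place, so their gaps to compound 3 give no step. The expectation for compound 4 is therefore no shift beyond the scatter, a step of a number 1.1 percentage points lower from compound 3 to compound 4 (within the scatter). Compound 4 is estimated at 32%, with a range from 20% to 45%.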

Compound 4, a percentage reported as inhibition, at one concentration (the size of the read-out at that concentration, not a potency): 29.1%
Estimate against measurement, compound 4: 2.9 percentage points above, and the stated range covers the measured number.
By their numbers in this assay, from the lowest: compounds 1, 4, 2 and 3 (each within the scatter of the next).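

Among these compounds, the step at the amine nitrogen in a ring gives the first reading of this position, since the earlier step concerned only the group on the thiocarbonyl carbon. In this assay, pyrazin-2-yl in place of (pyridin-4-yl)methyl gives a number 4 percentage points lower from compound 3 to compound 4 (within the scatter), so a change from 7 heavy atoms to 6, and from an aromatic ring with 1 hetero atom to one with 2 hetero atoms, leaves the read-out at this single concentration where it was, and compound 3 and compound 4 cannot be ranked. There is no measurement at hand that accounts for this result or says what either group does at this position.

The compounds shown leave open whether any group on this ring nitrogen can move the read-out beyond the scatter, for example a plain alkyl chain, an acetyl group or a carboxylic acid on a longer chain, each of which would put something other than an aromatic ring there. They also leave open whether these two groups would read alike in a potency measurement across several concentrations rather than at one.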